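One Added Methoxy on a Level Pair

A few compounds are considered here, and "the series" means these few. Any claim that something is new, unique, unknown or untested is made for them only; others in the source may bear on it.

In a functional assay on MCF7 cells (Homo sapiens) for inhibition, read by sulforhodamine B assay, with a stated time of 48 h (on this read-out lower numbers stand for stronger inhibition of growth and higher numbers for weaker inhibition of growth), compound 1 (`COc1cc(C(=O)NNC(=O)c2ccc3[nH]c(-c4ccc([N+](=O)[O-])s4)nc3c2)cc(OC)c1OC`) gives 31.3 ug/mL. Compound 2 (`COc1ccc(C(=O)NNC(=O)c2ccc3[nH]c(-c4ccc([N+](=O)[O-])o4)nc3c2)cc1OC`) gives 31.3 ug/mL, which places it level with compound 1, within the scatter. Among the compounds with values here, these two compounds differ in more than one place, so the data offer no measured single-change step as a guide. Compound 3 (`COc1cc(C(=O)NNC(=O)c2ccc3[nH]c(-c4ccc([N+](=O)[O-])o4)nc3c2)cc(OC)c1OC`) arises from compound 2 through one change (methoxy in place of hydrogen on an aromatic carbon), with methoxy in place of hydrogen on an aromatic carbon. Compound 1, which also carries that methoxy, reads 31.3 ug/mL, and on that ground no step beyond the scatter is expected in this assay, in either direction. As an estimate, this is no change at the digits printed from compound 2 to compound 3 (within the scatter). The expected value for compound 3 is 31.3 ug/mL, with an estimated range of 15 ug/mL to 65 ug/mL.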

Compound 3, concentration for 50% growth inhibition: 31.3 ug/mL
Compound 3: middle estimate and measured number agree at the digits printed; low and high end bracket the measured number.
By their numbers in this assay, from the lowest: compounds 1, 2 and 3 (each within the scatter of the next).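

In this assay, the first single-change readings show that methoxy in place of hydrogen on an aromatic carbon, ortho to a methoxy group and meta to a large group, gives a flat step (no change at the digits printed from compound 2 to compound 3 (within the scatter)). With that methoxy present, 5-nitrofuran-2-yl in place of 5-nitrothiophen-2-yl on an aromatic carbon is equally flat (no change at the digits printed from compound 1 to compound 3 (within the scatter)), so neither change shows a difference on this read-out. No measurement presented here bears on the reason for these level readings.

The compounds shown leave open whether an amine, a hydroxyl group or a longer alkoxy chain at this position would read differently. They also leave open whether the swap from 5-nitrothiophen-2-yl to 5-nitrofuran-2-yl would stay level on the methoxy pattern of compound 2.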